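Working notes: compound 4 and the group on the ring nitrogen

The source may report more compounds than this note shows. Statements on the series, on what has been measured and on what is new or still open speak of the compounds shown alone.

Compound 1 `Oc1cc(C(F)(F)F)ccc1-c1nc(-c2ccccc2O)n(-c2ccc(Cl)cc2)n1` is measured in a functional assay on PC-12 cells (Rattus norvegicus) for cytotoxicity, read by MTT assay, with stated times of 2 h and 24 h, tested at 5 uM (a higher number here means a stronger effect of the compound at the concentration tested, a lower number a weaker effect), at 87.3%. Compound 2 `Oc1cc(C(F)(F)F)ccc1-c1nc(-c2ccccc2O)n(-c2ccc(I)cc2)n1` gives 94.4% in this assay, and compound 3 `COc1ccc(-n2nc(-c3ccc(C(F)(F)F)cc3O)nc2-c2ccccc2O)cc1` gives 86.6%. All three numbers lie within the scatter of one another: the nearest neighbour of compound 1 is compound 3, with a number 0.7 percentage points lower from compound 1 to compound 3 (within the scatter), and the furthest is compound 2, with a number 7.1 percentage points higher from compound 1 to compound 2 (within the scatter); the remaining pair shows a number 7.8 percentage points lower from compound 2 to compound 3 (within the scatter).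

Compound 4 `Cc1ccc(-n2nc(-c3ccc(C(F)(F)F)cc3O)nc2-c2ccccc2O)c(C)c1` differs from compound 1 as follows: 2,4-dimethylphenyl in place of 4-chlorophenyl on an aromatic nitrogen. The three measured steps bear on this change only loosely, since each of them exchanges one substituent on an aromatic carbon of the group attached to the ring nitrogen, whereas here the whole group is exchanged. Each of those steps stayed within the scatter, so no step beyond the scatter is expected for this assay either. The expected step is a number 0.3 percentage points lower from compound 1 to compound 4 (within the scatter). Compound 4 is therefore estimated at 87%, with a range from 74% to 97%.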

Compound 4, a percentage reported as activity, at one concentration (the size of the read-out at that concentration, not a potency): 93.3%
Beside the measured number, compound 4's estimate is 6.3 percentage points below it, within the range that was stated.
By their numbers in this assay, from the lowest: compounds 3, 1, 4 and 2 (each within the scatter of the next).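

In this assay, exchanging the whole group on the aromatic nitrogen for 2,4-dimethylphenyl, which holds carbon only, gives no step beyond the scatter against any of the three earlier compounds (a number 6 percentage points higher from compound 1 to compound 4 (within the scatter); a number 6.7 percentage points higher from compound 3 to compound 4 (within the scatter); a number 1.1 percentage points lower from compound 2 to compound 4 (within the scatter)). The earlier steps shown here covered only single substituents on the group at this position, and the same holds for a group carrying two methyl substituents and neither halogen nor oxygen. Nothing at hand explains how this group acts at this position.

Open, going by these compounds, is whether an aminomethyl or carboxylic acid substituent on the phenyl ring, or a longer alkyl chain in place of that ring, would give a step beyond the scatter. Also open, on these data alone, is whether these four compounds would separate at a lower concentration.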